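The source may report more compounds than this note shows. Statements on the series, on what has been measured and on what is new or still open speak of the compounds shown alone.

Measured compounds:
compound 1, `O=c1cc(CSC(=S)N2CCCC2)oc2ccccc12`, > 30000 nM
compound 2, `O=c1cc(CSC(=S)N2CCCC2)oc2cc(Cl)ccc12`, > 25000 nM
compound 3, `O=c1c(CSC(=S)N2CCOCC2)coc2cc(Cl)ccc12`, 600 nM

In a functional assay on MDA-MB-435S cells (Homo sapiens) for antiproliferative activity, read by MTT assay, with a stated time of 72 h (on this read-out higher numbers stand for weaker inhibition and lower numbers for stronger inhibition), compound 2 reaches only a limit, > 25000 nM, and not a number. Compound 1 likewise stands at a limit, > 30000 nM. The step that the two limits leave unreadable from compound 1 to compound 2 therefore cannot be read, as both values sit at limits, the limit of > 25000 nM in this assay, at which 1 of the 3 values shown sits, and (the limit of > 30000 nM in this assay, at which 1 of the 3 values shown sits). Going by the values given here, compound 3, with the morpholin-4-yl group on a differently substituted core, gives 600 nM; no single step connects compound 3 to compound 2, so its value shows only that a morpholin-4-yl compound of this series can be measured. Compound 4, `O=c1cc(CSC(=S)N2CCOCC2)oc2cc(Cl)ccc12`, differs from compound 2 by morpholin-4-yl in place of pyrrolidin-1-yl on a thiocarbonyl carbon. Among the compounds with values here, none of the measured steps covers this change directly, so the expectation rests on the bare values. Compound 4 is expected at an estimated 12000 nM, within 1500 nM to 60000 nM. The step from compound 2 to compound 4 is thus expected to be an at least 2.0-fold lower number from compound 2 to compound 4 (0.31 log units; beyond the scatter).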

Compound 4, half-maximal inhibitory concentration: > 25000 nM
Compound 4: only a limit was reported; the forecaster's own chance of this, stated with the estimate: 45%; middle value at least 2.0-fold (0.31 log units) away from the limit.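

In this assay compound 4 gives only a limit (> 25000 nM) and not a number. Going by these compounds alone, compound 2 also stands at a limit, so no step between compound 2 and compound 4 can be read. The compounds shown leave open whether morpholin-4-yl in place of pyrrolidin-1-yl changes activity on this core at all.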